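A Fluoro-to-Hydrogen Change Seen Twice on One Core

The source may hold more compounds than are shown below. What is called first, only, known or untested is meant among the compounds shown, and "the series" means these compounds.

Compound 2 `O=C(Nc1ccc(OC(F)(F)F)c(F)c1)NC1CCN(C(=O)C2CCOCC2)CC1` and compound 3 `O=C(Nc1ccc(OC(F)(F)F)c(F)c1)NC1CCN(C(=O)C2CCCOC2)CC1` share a core and differ only by oxan-3-yl in place of oxan-4-yl on a carbonyl carbon. In an ADME assay on the whole organism (Mus musculus) for pharmacokinetics, at a dose of 0.3 mg/kg by the oral route (a lower number here means less compound in the circulation, a higher number more compound in the circulation at the dose given), compound 2 gives 332 nM, while compound 3 gives 112 nM, a step of a 3.0-fold lower number from compound 2 to compound 3 (0.47 log units; beyond the scatter). Compound 1 `O=C(Nc1ccc(OC(F)(F)F)cc1)NC1CCN(C(=O)C2CCOCC2)CC1` differs from compound 2 by hydrogen in place of fluoro on an aromatic carbon; in this assay compound 1 gives 381 nM, so the step is a 1.1-fold higher number from compound 2 to compound 1 (0.06 log units; within the scatter). Compound 4 `O=C(Nc1ccc(OC(F)(F)F)cc1)NC1CCN(C(=O)C2CCCOC2)CC1`, not yet measured, differs from compound 3 by hydrogen in place of fluoro on an aromatic carbon, the same change in the same place as that between compound 2 and compound 1. The expected step here is a 1.1-fold higher number from compound 3 to compound 4 (0.03 log units; within the scatter), set beside the earlier 1.1-fold higher number from compound 2 to compound 1 (0.06 log units; within the scatter), because a 1.1-fold higher number from compound 2 to compound 1 (0.06 log units; within the scatter) stayed within the scatter. Compound 4 is thus expected to give about 120 nM in this assay, most likely between 55 nM and 260 nM.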

Compound 4, maximal plasma concentration: 38 nM
Estimate against measurement, compound 4: 3.2-fold (0.50 log units) above; the whole stated range lies above it.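

In this assay, hydrogen in place of fluoro gives a 2.9-fold lower number from compound 3 to compound 4 (0.47 log units; beyond the scatter), so this change did not carry over unchanged from one core to the other: the same change on two cores in this assay, a 1.1-fold higher number (0.06 log units; within the scatter) from compound 2 to compound 1 and a 2.9-fold lower number (0.47 log units; beyond the scatter) from compound 3 to compound 4, 3.4-fold (0.53 log units) apart, beyond the scatter of two such steps. Oxan-3-yl in place of oxan-4-yl gives a 10-fold lower number from compound 1 to compound 4 (1.00 log units; beyond the scatter), and the size of this step also depends on the core: the same change on two cores in this assay, a 3.0-fold lower number (0.47 log units; beyond the scatter) from compound 2 to compound 3 and a 10-fold lower number (1.00 log units; beyond the scatter) from compound 1 to compound 4, 3.4-fold (0.53 log units) apart, beyond the scatter of two such steps. The two changes therefore do not act independently across these compounds, but the data show neither why this is so nor how either change would behave on a further core.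

The compounds shown leave open what a chlorine atom or a methyl group would do on that aromatic carbon. They also leave open whether an amine in place of the ring oxygen would show the same dependence on the core.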